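Cyclopropylmethyl amide in the spiro urea solubility series

The source may report more compounds than this note shows. Statements on the series, on what has been measured and on what is new or still open speak of the compounds shown alone.

Three amides of the shared core have been measured in an ADME assay for solubility, in simulated intestinal fluid; on this read-out lower numbers stand for lower solubility and higher numbers for higher solubility. Compound 1 `Cc1cnc(C(=O)N2CCC3(CC2)CN(C(=O)Nc2ccc(OC(F)(F)F)cc2)CCO3)cn1` gives 92 ug/mL. Among the compounds with values here, compound 2 `O=C(Nc1ccc(OC(F)(F)F)cc1)N1CCOC2(CCN(C(=O)c3ccccc3F)CC2)C1` gives 62 ug/mL; the single change between them, 2-fluorophenyl in place of 5-methylpyrazin-2-yl on a carbonyl carbon, gives a 1.5-fold lower number from compound 1 to compound 2 (0.17 log units; within the scatter). Compound 3 `O=C(Nc1ccc(C(F)(F)F)cc1)N1CCOC2(CCN(C(=O)c3c(F)cccc3F)CC2)C1` gives 38 ug/mL; its gap to compound 2 is within the scatter and its gap to compound 1 is beyond it. Compound 3 differs from compound 2 in two places, so the two values are noted without a step.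

Compound 4 `O=C(CC1CC1)N1CCC2(CC1)CN(C(=O)Nc1ccc(C(F)(F)F)cc1)CCO2` differs from compound 3 as cyclopropylmethyl in place of 2,6-difluorophenyl on a carbonyl carbon. Within the data shown here, the only measured step at this carbonyl carbon, from a heteroaryl to a fluorinated phenyl, stayed within the scatter; no measured step removes an aromatic ring here. On that basis compound 4 is expected to land near compound 3, with no step beyond the scatter. The expected step is a 1.3-fold higher number from compound 3 to compound 4 (0.12 log units; within the scatter). For compound 4 the estimate in this assay is 50 ug/mL, within 25 ug/mL to 100 ug/mL.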

Compound 4, solubility: 79 ug/mL
Beside the measured number, compound 4's estimate is 1.6-fold (0.20 log units) below it; the range from low to high includes it.
By their numbers in this assay, from the lowest: compounds 3, 2, 4 and 1 (each within the scatter of the next, the first and the last beyond it).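

In this assay, within the data shown here, cyclopropylmethyl in place of 2,6-difluorophenyl gives a 2.1-fold higher number from compound 3 to compound 4 (0.32 log units; beyond the scatter) and is the only measured step on this carbonyl carbon that lies beyond the scatter. Among these compounds, it is also the only step here that removes an aromatic ring, so a non-aromatic group on this carbonyl carbon carries no penalty on this read-out, at least with the trifluoromethyl urea of compound 3. The step swaps the ring type, removes both fluorines and reduces the heavy atoms from 8 to 4 all at once, and no available evidence bears on what drives the change.

Still open, on these data alone, is whether the same step holds with the trifluoromethoxy group of compound 2 on the urea. As far as these compounds go, it is also open how a longer alkyl chain or a saturated ring carrying an amine would read at this carbonyl carbon.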